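The source may hold more compounds than are shown below. What is called first, only, known or untested is meant among the compounds shown, and "the series" means these compounds.

Compound 2 `N#Cc1cccc(Cc2cnc(CCc3ccc(-c4ccccc4C(=O)O)cc3)[nH]2)c1` gives 812 nM in an in vitro functional assay on cells for agonist activity at Bombesin receptor subtype-3 (Homo sapiens), read by luminescence and calcium flux (a lower number here means that less compound is needed, a higher number that more compound is needed for the effect), the highest of the two numbers measured; its nearest neighbour, compound 1 `O=C(O)c1ccccc1-c1ccc(CCc2ncc(Cc3cccc(F)c3)[nH]2)cc1`, gives 159 nM. Compound 3 `O=C(O)c1ccccc1-c1ccc(CCc2ncc(Cc3ccc(F)cc3)[nH]2)cc1` differs from compound 2 in one place: 4-fluorophenyl in place of 3-cyanophenyl on a saturated chain carbon bound to an aromatic carbon. For the measured compounds named here, the only step that bears on this is a 5.1-fold higher number from compound 1 to compound 2 (0.71 log units; beyond the scatter), which compound 3 reverses while also changing where the fluorine stands; no measured step speaks to that second part. A lower number is therefore expected, of about the size of a 4.1-fold lower number from compound 2 to compound 3 (0.61 log units; beyond the scatter), with added uncertainty. Compound 3 is estimated at 200 nM, in a range of 60 nM to 700 nM.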

Compound 3, half-maximal effective concentration: 1600 nM
The estimate for compound 3 lay 8.0-fold (0.90 log units) below the measured number; measured number outside the range, above it.
By their numbers in this assay, from the lowest: compound 1; then compounds 2 and 3 (each within the scatter of the next).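

In this assay, a change in where the fluorine stands on the ring gives a 10-fold higher number from compound 1 to compound 3 (1.00 log units; beyond the scatter), so the place of the fluorine on this ring matters and fluorine alone does not secure the lower number. For the compounds shown here, with a 2.0-fold higher number from compound 2 to compound 3 (0.29 log units; within the scatter), 3-cyanophenyl and 4-fluorophenyl are not told apart, leaving 3-fluorophenyl as the one group here that stands apart from both. No measurement given here accounts for this.
The compounds shown leave open how unsubstituted phenyl, 3-chlorophenyl or 4-cyanophenyl would compare at this place.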